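Cyanoimino Group Replacing Thioimidate on the Pyridazinone Chain

The compounds below may be only part of what the source reports. "The series", "measured", "known", "first", "only" and "open" are said of these compounds alone.

Measured compounds:
Compound 1, `N#CNC(=N)NCCCCCn1nc(-c2ccccc2)ccc1=O`, gives 31%.
Compound 2, `N/C(S)=N/CCCCn1nc(-c2ccccc2)ccc1=O`, gives 72%.
Compound 3, `C/N=C(\S)N(C)CCCCn1nc(-c2ccccc2)ccc1=O`, gives 17.5%.

In a functional assay on the whole organism with Rattus norvegicus as the target, at a dose of 100 mg/kg (on this read-out higher numbers stand for more inhibition at the one dose given (going by the name of the read-out) and lower numbers for less inhibition), compound 3 stands lowest of the three measured compounds. Its nearest neighbour is compound 1, and the gap is a number 13.5 percentage points lower from compound 1 to compound 3 (beyond the scatter); the furthest is compound 2, with a number 54.5 percentage points lower from compound 2 to compound 3 (beyond the scatter). Compound 4, `C/N=C(/NC#N)N(C)CCCCn1nc(-c2ccccc2)ccc1=O`, differs from compound 3 by a group of 6 heavy atoms (3 carbon, 3 nitrogen; no ring) in place of a group of 4 heavy atoms (2 carbon, 1 nitrogen, 1 sulfur; no ring), on an amine nitrogen.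

For the measured compounds named here, the step bearing most on this change is the one from compound 1 to compound 3, a number 13.5 percentage points lower from compound 1 to compound 3 (beyond the scatter), since compound 4 brings back the cyano-bearing nitrogen that compound 3 lacks while keeping the methylated nitrogens of compound 3. The large step of a number 41 percentage points higher from compound 1 to compound 2 (beyond the scatter) involves a different group and offers no direct guide. A modest rise in this assay is therefore expected for compound 4, about a number 8.5 percentage points higher from compound 3 to compound 4 (within the scatter), though the shorter chain and the methyl groups make it uncertain. The estimate for compound 4 in this assay is 26%, with a range from 6% to 46%.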

Compound 4, a percentage reported as inhibition, in the whole organism at one dose (the size of the read-out at that dose, not a potency): 27%
Compound 4: the middle estimate sits 1 percentage points below what was measured; the measured number falls inside the stated range.
By their numbers in this assay, from the lowest: compounds 3, 4 and 1 (each within the scatter of the next, the first and the last beyond it); then compound 2.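

In this assay, the group of 6 heavy atoms (3 carbon, 3 nitrogen) in place of the group of 4 heavy atoms (2 carbon, 1 nitrogen, 1 sulfur) on an amine nitrogen gives a number 9.5 percentage points higher from compound 3 to compound 4 (within the scatter), so at this place the exchange of sulfur for the nitrile-bearing group does not separate the two compounds. The chain-end change also leaves compound 4 level with the earlier nitrile-bearing compound, at a number 4 percentage points lower from compound 1 to compound 4 (within the scatter). Only the comparison with the unmethylated sulfur compound stands out, at a number 45 percentage points lower from compound 2 to compound 4 (beyond the scatter), and compound 2 remains clear of compound 1, compound 3 and compound 4.

Nothing given here bears on why these numbers fall as they do. As far as these compounds go, whether a plain amine or a urea at this place on the chain of compound 2 would hold its level remains open.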